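Oxime ether series: lipophilicity step from compound 2 to 3

The source may report more compounds than this note shows. Statements on the series, on what has been measured and on what is new or still open speak of the compounds shown alone.

Two members of this series have a measurement. Compound 1 `CCO/N=C/Nc1cc(Cl)c(OCOC)c(Cl)c1` gives 3.7 in a physicochemical assay for lipophilicity, measured as octanol-water partition; on this read-out higher numbers stand for higher lipophilicity and lower numbers for lower lipophilicity. Compound 2 `C#CCc1c(Cl)cc(N/C=N/OC(C)C)cc1Cl` gives 3.9 in this assay. Among the compounds with values here, compound 2 holds the higher of the two numbers, but its nearest neighbour, compound 1, sits within the scatter of it, so the two values are not told apart by this assay; no single-point step connects them, and the two structures differ in more than one place.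

Within the data shown here, compound 3 `C#CCc1c(Cl)cc(N/C=N/OCCOCC)cc1Cl` has no measurement yet. Compared with compound 2 it carries 2-ethoxyethyl in place of isopropyl on an oxygen. The chain that enters is two heavy atoms longer than the one that leaves and brings one hydrogen-bond acceptor where there was none. Among the measured compounds shown here, no measured pair shows a change of this kind, so the size of the step is open.

The step from compound 2 to compound 3 is expected to be small and downward, a number 0.30 log units lower from compound 2 to compound 3 (within the scatter), probably at the edge of the scatter. For compound 3 the estimate in this assay is 3.6, with a range from 3.2 to 4.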

Compound 3, partition coefficient: 3.7
For compound 3 the middle estimate is 0.10 log units below the measured one, and the stated range covers the measured number.
By their numbers in this assay, from the lowest: compounds 1, 3 and 2 (each within the scatter of the next).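

Working notes on the oxygen that carries the oxime ether chain: the swap of isopropyl for 2-ethoxyethyl on this oxygen, whose other neighbour is the double-bonded nitrogen, gives the series its first single-point step, and in this assay that step is a number 0.20 log units lower from compound 2 to compound 3 (within the scatter) on the shared core. At this position, then, a chain of 5 heavy atoms with 1 hydrogen-bond acceptor replaces one of 3 heavy atoms with 0 acceptors, and this read-out does not tell compound 2 and compound 3 apart, something the earlier pair could not show since its members differ in more than one place. No measured evidence bears on why the step has this size.

With a single step, the contributions of the added length and the added chain oxygen cannot be separated, and an all-carbon longer chain on the same oxygen would be needed to address that. From the compounds shown here alone, how far this tolerance extends also stays open for a chain ending in an amine or a carboxylic acid, and for the same swap on the core of compound 1.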